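Working notes: from compound 2 to compound 4

This account rests on a few compounds, and the source may have more. Where it says the series, first, only, none or still open, it means among the compounds named here.

Measured in a functional assay on HL-60 cells (Homo sapiens) for cytotoxicity, read by MTT assay, with a stated time of 24 h; on this read-out higher numbers stand for weaker inhibition and lower numbers for stronger inhibition
- compound 1 `CN1CCN(CCCCCOc2c(Br)cc(Br)cc2Oc2ccc(Br)cc2Br)CC1` gives 48.3 ug/mL
- compound 2 `BrCCCCCCOc1c(Br)cc(Br)cc1Oc1ccc(Br)cc1Br` gives 37.8 ug/mL
- compound 3 `CC(C)(C)OC(=O)N1CCN(CCCCCOc2c(Br)cc(Br)cc2Oc2ccc(Br)cc2Br)CC1` gives 32.1 ug/mL

Compound 2 at 37.8 ug/mL cannot be separated from compound 1 or compound 3, since all three numbers lie within the scatter of one another. Compound 4 `C=CCOc1c(Br)cc(Br)cc1Oc1ccc(Br)cc1Br` departs from compound 2 by one change: vinyl in place of 5-bromopentyl on a saturated chain carbon bound to an oxygen on an aromatic ring. Going by the values given here, two measured steps bear on this, a 1.3-fold lower number from compound 1 to compound 2 (0.11 log units; within the scatter) and a 1.5-fold lower number from compound 1 to compound 3 (0.18 log units; within the scatter), and both stay within the scatter. Among the compounds with values here, neither removes the chain, so the data hold no direct precedent for the change. Given the size of those two steps, no shift beyond the scatter is expected in this assay, in either direction. The expected step is a 1.1-fold lower number from compound 2 to compound 4 (0.02 log units; within the scatter). Compound 4 is estimated at 36 ug/mL, with an expected range of 17 ug/mL to 70 ug/mL.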

Compound 4, half-maximal inhibitory concentration: 27.9 ug/mL
Beside the measured number, compound 4's estimate is 1.3-fold (0.11 log units) above it, and the stated range covers the measured number.
By their numbers in this assay, from the lowest: compounds 4, 3, 2 and 1 (each within the scatter of the next).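

In this assay, going by these compounds alone, the exchange of 5-bromopentyl for vinyl gives a 1.4-fold lower number from compound 2 to compound 4 (0.13 log units; within the scatter) and is the first step here that shortens the chain itself. At this position, neither the chain length of compound 2 nor its bromine is needed for a number within the scatter of compound 2. No evidence on hand accounts for this result.

On these data alone, whether a primary amine or a carboxylic acid on this chain would give a step beyond the scatter remains open. So does the effect of a free hydroxyl in place of the whole ether chain.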